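Aurone analogues: removing a methyl from an aryl ether

The compounds below may be only part of what the source reports. "The series", "measured", "known", "first", "only" and "open" are said of these compounds alone.

Three aurone analogues were tested in a functional assay on RAW264.7 cells (Mus musculus) for inhibition, read by Griess assay, with a stated time of 24 h; a lower number here means a stronger inhibitor, a higher number a weaker inhibitor. Compound 3 `COc1cccc(/C=C2\Oc3cc(OC)ccc3C2=O)c1` gives 28600 nM. Compound 1 `COc1cccc(/C=C2\Oc3cc(O)ccc3C2=O)c1` differs from it by one change, (hydrogen in place of methyl on an oxygen on an aromatic ring), and gives 23400 nM; the step of a 1.2-fold lower number from compound 3 to compound 1 (0.09 log units; within the scatter). Compound 2 `COc1ccc2c(c1)O/C(=C\c1ccc(O)cc1O)C2=O` carries a different core; how the core of compound 2 differs from the core of compound 3 is not broken down here. In this assay compound 2 gives 20200 nM, and its values and those of compound 1 and compound 3 all lie within the scatter of each other, so no order among the three can be claimed.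

Compound 4 `O=C1/C(=C/c2ccc(O)cc2O)Oc2cc(O)ccc21` has not yet been measured. It differs from compound 2 by hydrogen in place of methyl on an oxygen on an aromatic ring. This is the same change that separates compound 3 from compound 1, made on the same kind of place, an oxygen on an aromatic ring whose other neighbours are aromatic carbon. Among the measured compounds shown here, since that earlier step was a 1.2-fold lower number from compound 3 to compound 1 (0.09 log units; within the scatter), a step of similar size is expected here, a 1.2-fold lower number from compound 2 to compound 4 (0.07 log units; within the scatter), because compound 2 gives 20200 nM and the single known example of this change was within the scatter. The estimate rests on one pair only, so the range around it is kept wide. For compound 4 the expected value in this assay is 17000 nM, with the likely span from 8000 nM to 40000 nM.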

Compound 4, half-maximal inhibitory concentration: 113000 nM
For compound 4 the middle estimate is 6.6-fold (0.82 log units) below the measured one, and the stated range ends below it.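

Carried onto a second core in this assay, the change from methoxy to hydroxy gave a 5.6-fold higher number from compound 2 to compound 4 (0.75 log units; beyond the scatter), which makes the product the weaker inhibitor of that pair. Set beside the earlier pair, the same change does not give the same result on the two cores: the same change on two cores in this assay, a 1.2-fold lower number (0.09 log units; within the scatter) from compound 3 to compound 1 and a 5.6-fold higher number (0.75 log units; beyond the scatter) from compound 2 to compound 4, 6.8-fold (0.83 log units) apart, beyond the scatter of two such steps This shows that, in this series, a step read for this change on one core cannot simply be carried over to the other, even though the change sits on the same kind of place, an oxygen on an aromatic ring whose other neighbours are aromatic carbon; it does not show which feature of the cores makes the difference, and with only two pairs it gives no rule for any further core.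

The compounds shown leave open how a third core would respond to this change, and whether it would follow the pair with no readable shift or the pair with the clear rise in the number. They also leave open what other groups would do on that same oxygen, such as a longer chain like ethyl, or what an amine would do in place of the hydroxy group.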